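From Allyl to Phenyl on the Shared Core

A few compounds are considered here, and "the series" means these few. Any claim that something is new, unique, unknown or untested is made for them only; others in the source may bear on it.

Compound 2 `C=CCc1ccc([C@H]2CCN(C)C[C@H]2C(=O)OC)cc1` stands at the edge of what the numbers can show. In an assay on a subcellular fraction from brain for inhibition of Norepinephrine transporter (Rattus norvegicus) (on this read-out higher numbers stand for weaker inhibition and lower numbers for stronger inhibition), compound 2 gives > 1000 nM, which is a limit of the assay and not a number. Its partner compound 1 `C=Cc1ccc([C@H]2CCN(C)C[C@H]2C(=O)OC)cc1` carries a vinyl group where compound 2 carries allyl, and in this assay compound 1 gives 175 nM. Within the data shown here, the single measured step, an at least 5.7-fold higher number from compound 1 to compound 2 (0.75 log units; beyond the scatter), runs into (the limit of > 1000 nM in this assay, at which 1 of the 2 values shown sits), so its true size is open at the upper end.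

Compound 3 `COC(=O)[C@@H]1CN(C)CC[C@@H]1c1ccc(-c2ccccc2)cc1` differs from compound 2 by phenyl in place of allyl on an aromatic carbon. Among the measured compounds shown here, the measured step is the only guide, and it bears on the change only loosely, since it concerns a different group entering the same place. Replacing allyl with phenyl could move the number either way, and compound 2 offers no fixed starting point. Compound 3 is therefore expected to give about 800 nM in this assay, estimated to lie between 150 nM and 5000 nM. This expectation corresponds to an estimated step of an at least 1.2-fold lower number from compound 2 to compound 3 (0.09 log units; that floor lies within the scatter) from the limit of compound 2.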

Compound 3, inhibition constant: 203 nM
For compound 3 the middle estimate is 3.9-fold (0.60 log units) above the measured one, within the range that was stated.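

In this assay, the step of a 1.2-fold higher number from compound 1 to compound 3 (0.06 log units; within the scatter) places phenyl level with vinyl on this aromatic carbon, para to a large group, so the two groups cannot be told apart here. The step of an at least 4.9-fold lower number from compound 2 to compound 3 (0.69 log units; beyond the scatter) shows that the weak result with allyl does not carry over to a larger group: phenyl, with 6 heavy atoms against 3 for allyl, gives the lower number, so among these compounds the heavy-atom count of the group does not by itself set the reading. Compound 2 stands at a limit of the assay and not at a number, so this step has only a floor and its full size stays open: the limit of > 1000 nM in this assay, at which 1 of the 3 values shown sits.

The compounds shown leave open whether allyl stands apart through its extra carbon, which a saturated propyl chain or an ethyl group at the same place would help to decide. They also leave open how far this place tolerates a group carrying nitrogen or oxygen, such as an amine, a methoxy group or a carboxylic acid, in place of the carbon-only groups seen so far.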